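The compounds below may be only part of what the source reports. "The series", "measured", "known", "first", "only" and "open" are said of these compounds alone.

Measured so far:
compound 1 `CC(/C=N/Nc1ccc([N+](=O)[O-])cc1)=N\NC(=O)c1ccccc1Cl`: > 100000 nM
compound 2 `CC(/C=N/Nc1ccc([N+](=O)[O-])cc1)=N\NC(=O)c1ccccc1C`: > 100000 nM
compound 3 `CC(/C=N/Nc1ccc([N+](=O)[O-])cc1)=N\NC(=O)c1ccccc1I`: 40000 nM

In an ADME assay on J774 cells (Mus musculus, strain BALB/c) for cytotoxicity, read by resazurin assay, with a stated time of 72 h (on this read-out lower numbers stand for higher toxicity in this test and higher numbers for lower toxicity in this test), compound 1 gives only a limit, > 100000 nM. Compound 2 likewise gives only a limit, > 100000 nM. Within the data shown here, compound 3 gives the only number of the three, 40000 nM; the other two sit at the limit of > 100000 nM in this assay, at which 2 of the 3 values shown sit. The steps of an at least 2.5-fold lower number from compound 1 to compound 3 (0.39 log units; beyond the scatter) and an at least 2.5-fold lower number from compound 2 to compound 3 (0.39 log units; beyond the scatter) both lead to that number.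

Compound 4 `CC(/C=N/Nc1ccc([N+](=O)[O-])cc1)=N\NC(=O)c1ccc(Cl)cc1` is not yet measured; it differs from compound 3 by 4-chlorophenyl in place of 2-iodophenyl on a carbonyl carbon. Chloro replacing iodo reverses the direction of the step of an at least 2.5-fold lower number from compound 1 to compound 3 (0.39 log units; beyond the scatter), though at another ring position, so a return toward the limit is expected, meaning an expected step of a 2.5-fold higher number from compound 3 to compound 4 (0.40 log units; beyond the scatter). Compound 4 is therefore estimated at 100000 nM, within 40000 nM to 300000 nM.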

Compound 4, half-maximal cytotoxic concentration: 63900 nM
Compound 4: middle estimate off by 1.6-fold (0.19 log units), on the high side; the measured number falls inside the stated range.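

In this assay, a measured number does not depend on iodine: the 4-chlorophenyl group of compound 4 also gives one, and a 1.6-fold higher number from compound 3 to compound 4 (0.20 log units; within the scatter) shows no readable difference from the 2-iodophenyl group. The steps of an at least 1.5-fold lower number from compound 1 to compound 4 (0.19 log units; that floor lies within the scatter) and an at least 1.5-fold lower number from compound 2 to compound 4 (0.19 log units; that floor lies within the scatter) give only floors, so replacing 2-chlorophenyl or 2-methylphenyl with 4-chlorophenyl is not shown to exceed the scatter: the limit of > 100000 nM in this assay, at which 2 of the 4 values shown sit.

Still open, going by these compounds, is how an amine or a carboxylic acid in place of the chloro of compound 4 would read in this assay. Also open, on these data alone, is whether a 4-iodophenyl group would read like compound 3 or compound 4.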